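The source may hold more compounds than are shown below. What is called first, only, known or untested is meant among the compounds shown, and "the series" means these compounds.

Working notes on the series. Of the compounds shown here, three sharing one core have been read in a functional assay on MIA PaCa-2 cells (Homo sapiens) for inhibition, read by MTT assay, with a stated time of 72 h; on this read-out higher numbers stand for weaker inhibition and lower numbers for stronger inhibition. Compound 1 `COc1cc(NC(C)CCCNC(=O)Nc2cccc(Cl)c2)c2ncccc2c1` gives 21000 nM. Within the data shown here, compound 3 `COc1cc(NC(C)CCCNC(=O)Nc2ccc(C(F)(F)F)cc2)c2ncccc2c1` gives 8400 nM, the lowest of the two true numbers so far. Compound 2 `COc1cc(NC(C)CCCNC(=O)NNC(=O)Nc2ccc(Cl)cc2)c2ncccc2c1` gives >= 250000 nM, which is a limit of the assay and not a number. The two large steps involving that limit, an at least 11-fold higher number from compound 1 to compound 2 (1.07 log units; beyond the scatter) and an at least 29-fold lower number from compound 2 to compound 3 (1.47 log units; beyond the scatter), both turn on the ((4-chlorophenyl)carbamoyl)amino group and bear little on what follows.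

Next in line is compound 4 `COc1cc(NC(C)CCCNC(=O)Nc2ccc(Cl)cc2)c2ncccc2c1`, with chloro in place of trifluoromethyl on an aromatic carbon, para to a large group: chloro in place of trifluoromethyl on an aromatic carbon. The closest guide is a 2.5-fold lower number from compound 1 to compound 3 (0.40 log units; beyond the scatter), a modest step in which 4-(trifluoromethyl)phenyl replaces 3-chlorophenyl. That step also moves the substituent, so it bears only in part. On that basis, a small rise in the number is expected in this assay, not clearly beyond the scatter, towards compound 1 at 21000 nM. The expected step is a 1.7-fold higher number from compound 3 to compound 4 (0.22 log units; within the scatter). For compound 4 the estimate is 14000 nM, with an expected range of 6000 nM to 32000 nM.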

Compound 4, half-maximal inhibitory concentration: 22000 nM
Compound 4: the middle estimate sits 1.6-fold (0.20 log units) below what was measured; the range from low to high includes it.
By their numbers in this assay, from the lowest: compound 3; then compounds 1 and 4 (each within the scatter of the next). At a limit, above all of these: compound 2.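

With the position held fixed, the exchange on the aromatic carbon para to a large group can now be read by itself: in this assay, chloro in place of trifluoromethyl gives a 2.6-fold higher number from compound 3 to compound 4 (0.42 log units; beyond the scatter), whereas the earlier step from 3-chlorophenyl to 4-(trifluoromethyl)phenyl changed both the group and its place. Moving the chlorine alone gives a 1.0-fold higher number from compound 1 to compound 4 (0.02 log units; within the scatter), within the scatter, so 3-chlorophenyl and 4-chlorophenyl cannot be told apart here, and among these three compounds only the trifluoromethyl compound 3 stands apart from the others. Compound 2 stands at a limit and not a number, so an at least 11-fold lower number from compound 2 to compound 4 (1.05 log units; beyond the scatter) fixes only a bound on the step to 4-chlorophenyl on the amide-type nitrogen: the limit of >= 250000 nM in this assay, at which 1 of the 4 values shown sits.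

The compounds shown leave open how a nitrile, a methoxy or an amine on the same aromatic carbon would read against trifluoromethyl and chloro. They also leave open whether the difference between compound 3 and compound 4 would hold with a longer chain in place of the one in the shared core.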